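Enlarging the Ring on the Amide of a Shared Core

The source may report more compounds than this note shows. Statements on the series, on what has been measured and on what is new or still open speak of the compounds shown alone.

Three compounds share one core and differ only in the group on the ring nitrogen. Compound 1 `CCCCN1CCc2nc(C#Cc3ccccc3)sc2C1` carries a butyl chain, and in an assay on HEK293 cells for negative allosteric modulation of metabotropic glutamate receptor 5 (Homo sapiens), read by FLIPR, with a stated time of 1 h (a higher number here means a weaker inhibitor, a lower number a stronger inhibitor), compound 1 gives only the assay limit of > 10000 nM, not a number. Compound 2 `O=C(C1CC12CCC2)N1CCc2nc(C#Cc3ccccc3)sc2C1` carries a spiro-fused acyl group, and in this assay compound 2 likewise gives only the limit of > 10000 nM. Within the data shown here, compound 3 `O=C(C1CCC1)N1CCc2nc(C#Cc3ccccc3)sc2C1` carries a cyclobutylcarbonyl group, and in this assay compound 3 gives 370 nM, the only real number among the three. The steps of an at least 27-fold lower number from compound 1 to compound 3 (1.43 log units; beyond the scatter) and an at least 27-fold lower number from compound 2 to compound 3 (1.43 log units; beyond the scatter) are both large, and the step that the two limits leave unreadable from compound 1 to compound 2 cannot be read, since both ends sit at the limit (the limit of > 10000 nM in this assay, at which 2 of the 3 values shown sit).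

Compound 4 `O=C(C1CCCC1)N1CCc2nc(C#Cc3ccccc3)sc2C1` is not yet measured. It differs from compound 3 by cyclopentyl in place of cyclobutyl on a carbonyl carbon. Among the measured compounds shown here, the one measured step at the same place, an at least 27-fold lower number from compound 2 to compound 3 (1.43 log units; beyond the scatter), shows that a bulkier two-ring acyl group sent the number beyond the limit, whereas moving to cyclopentyl adds a single carbon to a plain ring. A small step in this assay, at most a modest rise, is therefore expected. Compound 4 is estimated to give 650 nM, within a range of 200 nM to 2500 nM. That estimate corresponds to an expected step of a 1.8-fold higher number from compound 3 to compound 4 (0.24 log units; within the scatter).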

Compound 4, half-maximal inhibitory concentration: > 10000 nM
Compound 4 ended at the assay's limit (the forecaster's own chance of this, stated with the estimate: 12%); at least 15-fold (1.18 log units) between middle value and limit.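

Cyclopentyl in place of cyclobutyl on a carbonyl carbon gives an at least 27-fold higher number from compound 3 to compound 4 (1.43 log units; beyond the scatter) in this assay, so a plain ring at this place can also lose the measurable number, not only the two-ring acyl group of compound 2. The change is small on paper, a five-membered non-aromatic ring of carbon only in place of a four-membered one, with no hydrogen-bond donor, acceptor or charge entering or leaving, yet among the acyl groups shown only the cyclobutylcarbonyl of compound 3 gives a real number. The steps among compound 1, compound 2 and compound 4 cannot be read, and these three cannot be ranked against each other, as each of them gives only a limit of the assay: the limit of > 10000 nM in this assay, at which 3 of the 4 values shown sit.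

From the compounds shown here alone, whether cyclopropyl on the carbonyl carbon would keep, improve or lose the activity of compound 3 remains open. Also open, going by these compounds, is whether a cyclobutyl ring carrying a methyl or a hydroxyl group, or a four-membered ring holding an oxygen atom, would keep a measurable number.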